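A few compounds are considered here, and "the series" means these few. Any claim that something is new, unique, unknown or untested is made for them only; others in the source may bear on it.

Measured in a functional assay on DU-145 cells (Homo sapiens) for inhibition, read by trypan blue exclusion, with a stated time of 96 h; a lower number here means a stronger inhibitor of growth, a higher number a weaker inhibitor of growth:

- compound 1 `COc1ccccc1/C=C(/SCc1ccc(Cl)c(Cl)c1)C(=O)c1ccc(Cl)cc1`: 10000 nM
- compound 2 `O=C(/C(=C\c1ccc(O)c([N+](=O)[O-])c1)SCc1ccc(Cl)cc1)c1ccc(Cl)cc1`: 10000 nM
- compound 3 `COc1ccccc1/C=C(/SCc1ccc(Cl)cc1)C(=O)c1ccc([N+](=O)[O-])cc1`: 10000 nM

The three measured compounds sit level with one another at the digits reported. Compound 3, at 10000 nM, is neither separated from compound 1 nor from compound 2, and its distance to each lies within the scatter. The account now turns to compound 4 `COc1ccccc1/C=C(/SCc1ccc(Cl)cc1)C(=O)c1ccc(Cl)cc1`, which has not yet been measured. It arises from compound 3 by one change, chloro in place of nitro on an aromatic carbon, para to a large group, so that 4-nitrophenyl becomes 4-chlorophenyl (chloro in place of nitro on an aromatic carbon).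

For the measured compounds named here, no two measured compounds differ in only one place, so the data offer no measured step by which to size this change. Going by the values given here, the only guide is the flat level of the series, with compound 3 at 10000 nM. On that basis, no step beyond the scatter is expected in this assay, though a stronger result cannot be excluded. The expected change is a 1.4-fold lower number from compound 3 to compound 4 (0.15 log units; within the scatter). The estimated value for compound 4 is 7000 nM, with an expected range from 1500 nM to 14000 nM.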

Compound 4, concentration for 50% growth inhibition: 1000 nM
The estimate for compound 4 lay 7.0-fold (0.85 log units) above the measured number; measured number below the stated range.
By their numbers in this assay, from the lowest: compound 4; then compounds 1, 2 and 3 (each within the scatter of the next).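

In this assay, for the compounds shown here, the change from 4-nitrophenyl to 4-chlorophenyl, on an aromatic carbon para to a large group, gives a 10-fold lower number from compound 3 to compound 4 (1.00 log units; beyond the scatter) and so shows that this position can move the number, which the level values of the earlier compounds could not show. Compound 4 also stands apart from its other two neighbours: hydrogen in place of chloro on an aromatic carbon gives a 10-fold lower number from compound 1 to compound 4 (1.00 log units; beyond the scatter) and 2-methoxyphenyl in place of 4-hydroxy-3-nitrophenyl gives a 10-fold lower number from compound 2 to compound 4 (1.00 log units; beyond the scatter) so that three separate single changes each lead to compound 4, the strongest inhibitor of growth of the four. Nothing available explains these steps, and no supporting measurement bears on them.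

The compounds shown leave open whether other groups at the same position, such as a bromo, a methyl, an amine or a carboxylic acid, would match chloro or fall back to the level of nitro. They also leave open whether the chloro on the aromatic carbon changed between compound 1 and compound 4 would give the same step on a different version of the shared core.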